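The source may hold more compounds than are shown below. What is called first, only, known or untested is meant among the compounds shown, and "the series" means these compounds.

Measured in a physicochemical assay for solubility, measured as kinetic solubility, at pH 7.4; a lower number here means a less soluble compound, a higher number a more soluble compound:
- compound 1 `CN(C)c1noc(-c2cccc(CN(C)c3ccc4[nH]nc(C(=O)O)c4c3)c2O)n1`: 135000 nM
- compound 2 `Cc1csc(-c2cccc(CNc3ccc4[nH]nc(C(=O)O)c4c3)c2O)n1`: 44000 nM
- compound 3 `CC(C)c1noc(-c2cccc(CNc3ccc4[nH]nc(C(=O)O)c4c3)c2O)n1`: 227000 nM

Among these three, compound 1 at 135000 nM lies within the usual scatter of compound 3 at 227000 nM. Its number is higher, beyond the scatter, than that of compound 2 at 44000 nM.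

The next compound to be read is compound 4 `CC(C)c1csc(-c2cccc(CN(C)c3ccc4[nH]nc(C(=O)O)c4c3)c2O)n1`. It keeps the core of compound 1 and puts 4-isopropyl-1,3-thiazol-2-yl in place of 3-(dimethylamino)-1,2,4-oxadiazol-5-yl on an aromatic carbon, ortho to a hydroxy group: 4-isopropyl-1,3-thiazol-2-yl in place of 3-(dimethylamino)-1,2,4-oxadiazol-5-yl on an aromatic carbon.

Among the measured compounds shown here, one measured step bears on this exchange, and it runs the opposite way: a 5.2-fold higher number from compound 2 to compound 3 (0.71 log units; beyond the scatter). That step is modest, and it swaps a thiazolyl group for an oxadiazolyl group. The groups in it do not match those in compound 1 and compound 4, and the cores of compound 2 and compound 3 also differ from that of compound 1, so it is only a rough guide.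

Reversing it, a modest drop in this assay is expected, beyond the scatter. The estimated step is a 4.5-fold lower number from compound 1 to compound 4 (0.65 log units; beyond the scatter). For compound 4 the estimated value is 30000 nM, with an expected range from 9000 nM to 90000 nM.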

Compound 4, solubility: 6000 nM
Estimate against measurement, compound 4: 5.0-fold (0.70 log units) above; the measured number lies below the stated range.
By their numbers in this assay, from the lowest: compound 4; then compound 2; then compounds 1 and 3 (each within the scatter of the next).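

In this assay, the exchange on the aromatic carbon ortho to a hydroxy group, 4-isopropyl-1,3-thiazol-2-yl in place of 3-(dimethylamino)-1,2,4-oxadiazol-5-yl, gives a 23-fold lower number from compound 1 to compound 4 (1.35 log units; beyond the scatter), a large step at this position on the core of compound 1. Read beside the earlier pair, a 5.2-fold higher number from compound 2 to compound 3 (0.71 log units; beyond the scatter), it shows that the compound with the oxadiazolyl group has the higher number in both pairs, though the two pairs differ in their groups and their cores, so the different sizes of the steps cannot be assigned to any single feature. Nothing shown here accounts for the size of the new step.

Because the ring and its substituent change together in this exchange, the compounds leave open how much of the step goes with the five-membered ring and how much with the move from dimethylamino to isopropyl. From the compounds shown here alone, a thiazolyl group carrying a dimethylamino substituent at this position would bear on that question, and how it would read in this assay remains open.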